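The source may hold more compounds than are shown below. What is called first, only, known or untested is meant among the compounds shown, and "the series" means these compounds.

Measured in an ADME assay on NHDF cells (Homo sapiens) for cytotoxicity, read by MTT assay, with a stated time of 72 h; a higher number here means a weaker inhibitor, a lower number a stronger inhibitor:
Compound 1 `COc1cccc(/C=C2\CCC/C(=C\c3ccc(Br)cc3)C2=O)c1OC`: 21400 nM
Compound 2 `COc1ccc(/C=C2\CCC/C(=C\c3cccc(OC)c3OC)C2=O)cc1`: 43500 nM
Compound 3 `COc1cccc(/C=C2\CCC/C(=C\c3cccc(O)c3)C2=O)c1OC`: 19300 nM

Compound 3 stands with compound 1 at the low end of these three numbers, and compound 2 stands apart, with a 2.3-fold lower number from compound 2 to compound 3 (0.35 log units; beyond the scatter). Compound 4 `COc1cccc(/C=C2\CCC/C(=C\c3ccc(Cl)c(Cl)c3)C2=O)c1OC` carries one change: 3,4-dichlorophenyl in place of 3-hydroxyphenyl on a double-bonded chain carbon bound to a double-bonded ring carbon. Among the compounds with values here, two measured steps bear on it. Exchanging the groups at this place on compound 1 gave a 1.1-fold lower number from compound 1 to compound 3 (0.04 log units; within the scatter), and compound 1, the nearest analogue, has a 4-bromophenyl there. Replacing bromo with methoxy gave only a 2.0-fold higher number from compound 1 to compound 2 (0.31 log units; beyond the scatter). Within the data shown here, no measured compound carries 3,4-dichlorophenyl, so the expectation is no step beyond the scatter. The estimate is a 1.0-fold higher number from compound 3 to compound 4 (0.02 log units; within the scatter). Compound 4 is expected at 20000 nM, with an estimated range of 9000 nM to 42000 nM.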

Compound 4, half-maximal inhibitory concentration: 25500 nM
Compound 4: middle estimate off by 1.3-fold (0.11 log units), on the low side, and the stated range covers the measured number.
By their numbers in this assay, from the lowest: compounds 3, 1, 4 and 2 (each within the scatter of the next, the first and the last beyond it).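

In this assay the step of a 1.3-fold higher number from compound 3 to compound 4 (0.12 log units; within the scatter) lies within the scatter, and so do a 1.2-fold higher number from compound 1 to compound 4 (0.08 log units; within the scatter) and a 1.7-fold lower number from compound 2 to compound 4 (0.23 log units; within the scatter) on this double-bonded chain carbon. Exchanging 3-hydroxyphenyl, with its hydrogen-bond donor, for 3,4-dichlorophenyl, with none, thus leaves the number within the scatter, and compound 4 cannot be separated from compound 2, although compound 3 can. No measurement at hand explains these results. On these data alone, whether an amine or a carboxylic acid on the aromatic ring at this place would give a step beyond the scatter remains open.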